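Swapping the triazole substituent in a cytotoxicity series

The source may hold more compounds than are shown below. What is called first, only, known or untested is meant among the compounds shown, and "the series" means these compounds.

Of the compounds shown here, three sharing one core have been tested in a functional assay on THP-1 cells (Homo sapiens) for cytotoxicity, read by MTT assay, with a stated time of 24 h; a higher number here means a weaker inhibitor, a lower number a stronger inhibitor. Compound 1 `Nc1nn(Cc2cn(-c3ccc(O)c([N+](=O)[O-])c3)nn2)c2nc(-c3ccccc3)cc(C(F)(F)F)c12` gives 36.3 ug/mL. Compound 2 `COc1ccc(NC(=O)Cn2cc(Cn3nc(N)c4c(C(F)(F)F)cc(-c5ccccc5)nc43)nn2)cc1` gives 56.7 ug/mL, and compound 3 `Nc1nn(Cc2cn(CC(=O)Nc3cccc(Cl)c3)nn2)c2nc(-c3ccccc3)cc(C(F)(F)F)c12` gives 37 ug/mL. Compound 1 sits at the low end of these three numbers, but its steps to the others stay within the scatter: a 1.0-fold higher number from compound 1 to compound 3 (0.01 log units; within the scatter) and a 1.6-fold higher number from compound 1 to compound 2 (0.19 log units; within the scatter). The comparison between the two amide-bearing compounds, a 1.5-fold lower number from compound 2 to compound 3 (0.19 log units; within the scatter), is likewise within the scatter.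

Compound 4 `Nc1nn(Cc2cn(CC(=O)Nc3cccc(F)c3)nn2)c2nc(-c3ccccc3)cc(C(F)(F)F)c12` is not yet measured in this assay. It differs from compound 1 by ((3-fluorophenyl)carbamoyl)methyl in place of 4-hydroxy-3-nitrophenyl on an aromatic nitrogen. The two measured steps that bear on this change are those from compound 1 to compound 2 and from compound 1 to compound 3, which replace the same group on the same aromatic nitrogen with closely related carbamoylmethyl groups; neither moved the number beyond the scatter. Compound 4 is therefore expected to give a step of a 1.0-fold higher number from compound 1 to compound 4 (0.02 log units; within the scatter), that is, no change beyond the scatter. The estimated value for compound 4 in this assay is 38 ug/mL, with a range from 20 ug/mL to 72 ug/mL.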

Compound 4, half-maximal inhibitory concentration: 99.5 ug/mL
The estimate for compound 4 lay 2.6-fold (0.42 log units) below the measured number; the measured number lies above the stated range.
By their numbers in this assay, from the lowest: compounds 1, 3, 2 and 4 (each within the scatter of the next, the first and the last beyond it).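

In this assay, fluoro in place of chloro on an aromatic carbon gives a 2.7-fold higher number from compound 3 to compound 4 (0.43 log units; beyond the scatter) even though the rest of the structure stays the same, so a single atom on this phenyl ring can move the number beyond the scatter. Within the data shown here, replacing 4-hydroxy-3-nitrophenyl on the aromatic nitrogen with ((3-fluorophenyl)carbamoyl)methyl gives a 2.7-fold higher number from compound 1 to compound 4 (0.44 log units; beyond the scatter) and is the first such replacement here to go beyond the scatter, whereas a 1.8-fold higher number from compound 2 to compound 4 (0.24 log units; within the scatter) does not separate 3-fluorophenyl from 4-methoxyphenyl on the amide-type nitrogen. No measurement at hand accounts for the gap between the fluoro and chloro compounds.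

From the compounds shown here alone, what a 3-bromophenyl or an unsubstituted phenyl group on the amide-type nitrogen would give remains open. So does the effect of a longer chain between the aromatic nitrogen and the amide carbonyl.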